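Cyclopropylsulfonyl to dimethylsulfamoyl on a shared core

A few compounds are considered here, and "the series" means these few. Any claim that something is new, unique, unknown or untested is made for them only; others in the source may bear on it.

Measured so far:
compound 1, `Oc1cccc2c1CCCC2c1c[nH]cn1`, 145 nM
compound 2, `CS(=O)(=O)Nc1ccc(Cl)c2c1CCCC2c1c[nH]cn1`, < 10000 nM
compound 3, `O=S(=O)(Nc1cccc2c1CCCC2c1c[nH]cn1)C1CC1`, < 10000 nM

Of the compounds shown here, three have been measured in an assay on isolated protein (Cricetulus griseus) for binding affinity to Alpha-1B adrenergic receptor (Mesocricetus auratus), read by radioligand binding; on this read-out higher numbers stand for weaker inhibition and lower numbers for stronger inhibition. Among the compounds with values here, compound 1 is the only one with a full number, giving 145 nM. For compound 3 the result is a limit of the assay, < 10000 nM, and not a number. Compound 2 likewise stands at a limit, < 10000 nM. The step that the limit leaves unreadable from compound 1 to compound 3 is therefore not readable in size, and the same holds for any comparison between compound 2 and compound 3, both of which sit at the limit of < 10000 nM in this assay, at which 2 of the 3 values shown sit.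

Compound 4 `CN(C)S(=O)(=O)Nc1cccc2c1CCCC2c1c[nH]cn1` differs from compound 3 by dimethylamino in place of cyclopropyl on a sulfonyl sulfur. Within the data shown here, no measured step speaks to this change: the only step touching compound 3 is unreadable, and the two sulfonamides are both limits. What is known is that compound 1 binds and that both sulfonyl-bearing analogues have not given a number, so compound 4 is expected to resemble compound 3 more than compound 1, with the step that the limit leaves unreadable from compound 3 to compound 4 expected to be small. Compound 4 is estimated at 3000 nM, within 400 nM to 10000 nM, and a further limit rather than a number is a real possibility.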

Compound 4, inhibition constant: < 10000 nM
Compound 4 gave a limit, no number (the forecaster's own chance of this, stated with the estimate: 45%); the middle value does not contradict the limit.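

In this assay compound 4 gives < 10000 nM, a limit of the assay and not a number. Within the data shown here, no step from compound 1 or compound 3 to compound 4 can be read in size. The compounds shown leave open how dimethylamino compares with cyclopropyl on a sulfonyl sulfur, and how strongly compound 3 and compound 4 bind.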